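This account rests on a few compounds, and the source may have more. Where it says the series, first, only, none or still open, it means among the compounds named here.

Measured so far:
Compound 1, `Brc1cn2ccnc2c(-c2ccc3ncn(C4CCCCC4)c3c2)n1` — in a functional assay on NCI-H226 cells (Homo sapiens) for inhibition, read by sulforhodamine B assay, with a stated time of 48 h, tested at 10 uM (on this read-out lower numbers stand for less inhibition and higher numbers for more inhibition at the one concentration tested (going by the name of the read-out)), compound 1 gives 22.5%
Compound 2, `COc1ccccc1-c1cn2ccnc2c(-c2ccc3ncn(C4CCCCC4)c3c2)n1` — in this assay compound 2 gives 25.7%

Among the measured compounds shown here, on these two numbers compound 1 sits at the smaller end, but the one step available, a number 3.2 percentage points higher from compound 1 to compound 2 (within the scatter), is within the scatter, so compound 1 and compound 2 cannot really be told apart. Compound 3, `FC(F)(F)c1cccc(-c2cn3ccnc3c(-c3ccc4ncn(C5CCCCC5)c4c3)n2)c1`, is the next compound to be tested. It differs from compound 1 in this way: 3-(trifluoromethyl)phenyl in place of bromo on an aromatic carbon. For the measured compounds named here, the only measured step that bears on this change is the one from compound 1 to compound 2, where a different six-membered aromatic ring of carbon only took the place of bromo on the same aromatic carbon, and that step was a number 3.2 percentage points higher from compound 1 to compound 2 (within the scatter). On this basis the step expected for compound 3 in this assay is a number 2.5 percentage points higher from compound 1 to compound 3 (within the scatter), that is, none beyond the scatter. Compound 3 is therefore estimated at 25%, within a range from 10% to 42%.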

Compound 3, a percentage reported as inhibition, at one concentration (the size of the read-out at that concentration, not a potency): 1.55%
Compound 3: middle estimate off by 23.5 percentage points, on the high side, and the stated range ends above it.
By their numbers in this assay, from the lowest: compound 3; then compounds 1 and 2 (each within the scatter of the next).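

In this assay, this position proves sensitive to what it carries: placing 3-(trifluoromethyl)phenyl here in place of bromo gives a number 21 percentage points lower from compound 1 to compound 3 (beyond the scatter), and placing it here in place of 2-methoxyphenyl gives a number 24.2 percentage points lower from compound 2 to compound 3 (beyond the scatter). Adding a six-membered aromatic ring of carbon at this position therefore does not fix the result by itself, since two such rings with different groups on them give clearly different numbers. No available evidence accounts for this difference.

The two rings differ both in the group they carry and in where they carry it, so the compounds shown cannot separate these two influences. They also leave open how this position would respond to a different kind of group, such as an amine, a carboxylic acid or a longer chain.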